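This account rests on a few compounds, and the source may have more. Where it says the series, first, only, none or still open, it means among the compounds named here.

Working notes on the series. Compound 1 `C[C@H](NC(=O)c1c(Cc2cccc(Cl)c2)sc2c1CCOC2)c1ccc(C(=O)O)cc1` carries a 3-chlorobenzyl on the aromatic carbon next to the ring sulfur of the shared core; in a functional assay on CHO/Galpha16 cells for antagonist activity at prostaglandin E2 receptor EP4 subtype (Homo sapiens), read by calcium flux, with a stated time of 15 min (on this read-out higher numbers stand for weaker inhibition and lower numbers for stronger inhibition), compound 1 gives 3.2 nM. Compound 2 `C[C@H](NC(=O)c1c(C#Cc2ccc(F)cc2)sc2c1CCOC2)c1ccc(C(=O)O)cc1` carries a 2-(4-fluorophenyl)ethynyl at the same place; in this assay compound 2 gives 15.8 nM. For the measured compounds named here, compound 2 holds the higher of the two numbers measured so far, and the only step available is a 4.9-fold higher number from compound 1 to compound 2 (0.69 log units; beyond the scatter).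

Compound 3 `COc1cccc(Cc2sc3c(c2C(=O)N[C@@H](C)c2ccc(C(=O)O)cc2)CCOC3)c1` differs from compound 2 by 3-methoxybenzyl in place of 2-(4-fluorophenyl)ethynyl on an aromatic carbon. Going by the values given here, the change brings back a benzyl group of the kind present in compound 1, with a methoxy where compound 1 has a chloro, so the single measured step bears on it in reverse: the number rose on a 4.9-fold higher number from compound 1 to compound 2 (0.69 log units; beyond the scatter) when benzyl gave way to ethynyl, and the move back is expected to lower it by about the same amount. Among the compounds with values here, no step covers methoxy against chloro on the benzyl, so that part stays open. Compound 3 is therefore expected to give about 4 nM in this assay, within 1.5 nM to 12 nM, meaning a step of a 4.0-fold lower number from compound 2 to compound 3 (0.60 log units; beyond the scatter).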

Compound 3, half-maximal inhibitory concentration: 1.9 nM
The estimate for compound 3 lay 2.1-fold (0.32 log units) above the measured number, within the range that was stated.
By their numbers in this assay, from the lowest: compounds 3 and 1 (each within the scatter of the next); then compound 2.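

In this assay, 3-methoxybenzyl in place of 2-(4-fluorophenyl)ethynyl at this position gives an 8.3-fold lower number from compound 2 to compound 3 (0.92 log units; beyond the scatter), so the gap to the ethynyl compound now appears with a second benzyl group and no longer rests on 3-chlorobenzyl alone. Methoxy in place of chloro on the benzyl ring gives a 1.7-fold lower number from compound 1 to compound 3 (0.23 log units; within the scatter), which is within the scatter, so this read-out does not separate the two substituents here. Among the three compounds, both benzyl groups therefore stand apart from the ethynyl group by steps beyond the scatter, and no compound shown goes against this.

The benzyl and ethynyl groups differ in both the link to the ring and the substituent on the phenyl ring, so the compounds shown leave open how much of the step belongs to each, and an unsubstituted benzyl or a benzyl carrying a dimethylamino group would extend the comparison. No measurement is at hand that bears on the reason for these steps.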